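Swapping carbamoyl for hydroxymethyl in compound 1

The source may hold more compounds than are shown below. What is called first, only, known or untested is meant among the compounds shown, and "the series" means these compounds.

Compound 1 `Cc1cc(/C=C/C#N)cc(C)c1Oc1cc(Nc2ccc(C#N)cc2)c(N)cc1C(N)=O` is the starting point in an in vitro ADME assay on microsomes from liver (Homo sapiens) for metabolic stability, tested at 1 uM (a higher number here means that the compound lasts longer, a lower number that the compound disappears faster), where compound 1 gives 0.583 h. Two relatives share its core: compound 3 `Cc1cc(CCC#N)cc(C)c1Oc1cc(Nc2ccc(C#N)cc2)c(N)cc1C(N)=O` gives 0.7 h and compound 2 `Cc1cc(CCC#N)cc(C)c1Oc1cc(Nc2ccc(C#N)cc2)c(N)cc1C(F)(F)F` gives 0.928 h. All three numbers sit within the scatter of one another, so compound 1 stands level with both.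

Compound 4 `Cc1cc(/C=C/C#N)cc(C)c1Oc1cc(Nc2ccc(C#N)cc2)c(N)cc1CO` has not yet been measured. It differs from compound 1 by hydroxymethyl in place of carbamoyl on an aromatic carbon, which is hydroxymethyl in place of carbamoyl on an aromatic carbon. Among the measured compounds shown here, two measured steps bear on this. Putting carbamoyl in place of trifluoromethyl at that same place gave a 1.3-fold lower number from compound 2 to compound 3 (0.12 log units; within the scatter). A change elsewhere, 2-cyanoethyl in place of 2-cyanoethenyl, gave a 1.2-fold higher number from compound 1 to compound 3 (0.08 log units; within the scatter). For the measured compounds named here, both stayed within the scatter, but no measured compound carries hydroxymethyl, so they are only a loose guide. In this assay the expected result is a 1.0-fold higher number from compound 1 to compound 4 (0.01 log units; within the scatter), which means no step beyond the scatter. The estimate for compound 4 is 0.6 h, with an expected range from 0.3 h to 1.2 h.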

Compound 4, half-life: 0.503 h
Compound 4: the middle estimate sits 1.2-fold (0.08 log units) above what was measured; the measured number falls inside the stated range.
By their numbers in this assay, from the lowest: compounds 4, 1, 3 and 2 (each within the scatter of the next).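

In this assay, hydroxymethyl in place of carbamoyl on this aromatic carbon gives a 1.2-fold lower number from compound 1 to compound 4 (0.06 log units; within the scatter) and so stays within the scatter. Among the compounds shown here, the earlier compounds showed only carbamoyl and trifluoromethyl at this place, so this adds a third group and the first change here on the 2-cyanoethenyl compounds. Going from 3 heavy atoms to 2 and losing the double bond of the carbamoyl, while keeping 1 hydrogen-bond donor and 1 hydrogen-bond acceptor, leaves the half-life level, though no supporting measurement here explains that result.

The compounds shown leave open whether a carboxylic acid, an amine or a longer chain such as 2-hydroxyethyl at this place would also stay level. They also leave open whether hydroxymethyl gives the same result alongside 2-cyanoethyl.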